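From Methoxy to Methoxycarbonyl on the Urea Aryl Ring

The source may hold more compounds than are shown below. What is called first, only, known or untested is meant among the compounds shown, and "the series" means these compounds.

Compound 1: `O=C(Nc1ccc([N+](=O)[O-])cc1)N[C@H]1CC[C@H](Oc2ccc(F)cc2)CC1` — 2300 nM
Compound 2: `COc1ccc(NC(=O)N[C@H]2CC[C@H](Oc3ccc(F)cc3)CC2)cc1` — > 20000 nM

Two ureas sharing one core have been tested in a functional assay on CRL2813 cells (Homo sapiens) for cytotoxicity, read by sulforhodamine B assay, with a stated time of 5 days; a lower number here means a stronger inhibitor, a higher number a weaker inhibitor. Compound 1 gives 2300 nM. Compound 2 reaches only (the limit of > 20000 nM in this assay, at which 1 of the 2 values shown sits), so its value is a limit of the assay and not a number. Among the compounds with values here, the single measured step, an at least 8.6-fold higher number from compound 1 to compound 2 (0.93 log units; beyond the scatter), therefore marks a clear loss of potency.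

Compound 3, `COC(=O)c1ccc(NC(=O)N[C@H]2CC[C@H](Oc3ccc(F)cc3)CC2)cc1`, is not yet measured. It differs from compound 2 by methoxycarbonyl in place of methoxy on an aromatic carbon.

Since compound 2 sits at the limit, no further weakening can be seen; the only measurable outcome is a lower number or another limit. The measured step from nitro to methoxy gives no direct guide for methoxycarbonyl, so the expectation is cautious. Compound 3 is expected to give about 9000 nM, between 2500 nM and 30000 nM, meaning an estimated step of an at least 2.2-fold lower number from compound 2 to compound 3 (0.34 log units; beyond the scatter).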

Compound 3, half-maximal inhibitory concentration: 11600 nM
Estimate against measurement, compound 3: 1.3-fold (0.11 log units) below; the range from low to high includes it.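

Replacing nitro with methoxycarbonyl gives a 5.0-fold higher number from compound 1 to compound 3 (0.70 log units; beyond the scatter) in this assay, so a second group at this place, para to a large group, has a higher number than nitro, and this time the size of the change is measured. The value of compound 2 is a limit of the assay and not a number: the limit of > 20000 nM in this assay, at which 1 of the 3 values shown sits. Replacing methoxy with methoxycarbonyl gives an at least 1.7-fold lower number from compound 2 to compound 3 (0.23 log units; that floor lies within the scatter) and this floor lies within the scatter, so a real gain over methoxy is possible but not established.

From the compounds shown here alone, what an amine or a carboxylic acid at this place would give remains open. The three compounds also cannot say why nitro has the lowest number here, or how far compound 2 lies beyond its limit.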